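This account rests on a few compounds, and the source may have more. Where it says the series, first, only, none or still open, it means among the compounds named here.

Working notes on the series.

Compound 1 `C=C(Br)C(=O)Nc1ccc(C(=O)/C=C/c2ccc(OC)cc2)cc1` carries a bromo-acrylamide on one ring and a single methoxy on the other. In a functional assay on FM3A cells (Mus musculus) for antiproliferative activity, with a stated time of 48 h (on this read-out lower numbers stand for stronger inhibition and higher numbers for weaker inhibition), compound 1 gives 1000 nM. Compound 2 `C=C(Br)C(=O)Nc1ccc(C(=O)/C=C/c2ccc(OC)cc2OC)cc1` adds a methoxy to the same ring; the change is methoxy in place of hydrogen on an aromatic carbon, and in this assay compound 2 gives 1200 nM, so the step is a 1.2-fold higher number from compound 1 to compound 2 (0.08 log units; within the scatter). Compound 3 `C=C(Br)C(=O)Nc1ccc(C(=O)/C=C/c2cc(OC)cc(OC)c2)cc1` places two methoxy groups on that ring in a different arrangement; the difference between the cores of compound 1 and compound 3 is not broken down here. In this assay compound 3 gives 2000 nM, and the gaps from compound 3 to compound 2 and to compound 1 are described as within the scatter.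

Compound 4 `C=C(Br)C(=O)Nc1ccc(C(=O)/C=C/c2cc(OC)c(OC)c(OC)c2)cc1` is not yet measured. It arises from compound 3 by methoxy in place of hydrogen on an aromatic carbon, the same kind of change as that from compound 1 to compound 2. The surroundings differ: in compound 2 the entering methoxy sits ortho to a large group and meta to a methoxy group, whereas in compound 4 it sits ortho to two methoxy groups and para to a large group. Going by the values given here, the one measured instance of this change, a 1.2-fold higher number from compound 1 to compound 2 (0.08 log units; within the scatter), lay within the scatter, and the three measured values all lie within the scatter of one another, so no clear direction is available from the series itself.

For compound 4 in this assay the step is therefore expected to be small, a 1.3-fold lower number from compound 3 to compound 4 (0.12 log units; within the scatter), resting on the measured step from compound 1 to compound 2 and on compound 3 giving 2000 nM. The estimate for compound 4 in this assay is 1500 nM, expected to fall between 600 nM and 4000 nM.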

Compound 4, half-maximal inhibitory concentration: 1800 nM
For compound 4 the middle estimate is 1.2-fold (0.08 log units) below the measured one, and the stated range covers the measured number.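

In this assay methoxy in place of hydrogen on an aromatic carbon now reads as a 1.1-fold lower number from compound 3 to compound 4 (0.05 log units; within the scatter), here with the entering methoxy ortho to two methoxy groups and para to a large group. Set beside the earlier instance of the change, the new step shows no measurable difference between the two cores: the same change on two cores in this assay, a 1.2-fold higher number (0.08 log units; within the scatter) from compound 1 to compound 2 and a 1.1-fold lower number (0.05 log units; within the scatter) from compound 3 to compound 4, 1.3-fold (0.12 log units) apart, within the scatter of two such steps This supports only a narrow reading, that on the core of compound 1 and the core of compound 3 the change stays within the scatter; it gives no direction for the change and does not show that the step would stay this small on any other core in the series.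

The compounds shown leave open whether a different group on the same ring, such as a hydroxyl, an amine or a longer alkoxy chain, would produce a step beyond the scatter. As far as these compounds go, all four compounds also carry the same bromo-acrylamide, so what happens to the methoxy step, or to the values themselves, with a plain acrylamide or a chloro-acrylamide in its place remains open.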